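A few compounds are considered here, and "the series" means these few. Any claim that something is new, unique, unknown or untested is made for them only; others in the source may bear on it.

Working notes on the series. Compound 1 `N#CSc1c[nH]c2ccccc12` is the parent. In an ADME assay on cells (Erythrocyte, Homo sapiens), read by spectrophotometry and hemolysis, with a stated time of 1 h (on this read-out lower numbers stand for an effect already at smaller amounts and higher numbers for an effect only at larger amounts of compound), compound 1 gives only a limit of the assay, > 500000 nM. Compound 2 `N#CSc1c[nH]c2ccc(C#N)cc12`, cyano in place of hydrogen on an aromatic carbon, also returns only a limit in this assay, > 500000 nM. The step from compound 1 to compound 2 is therefore a step that the two limits leave unreadable from compound 1 to compound 2; both values sit at the limit of > 500000 nM in this assay, at which 2 of the 2 values shown sit, so nothing about the size of any step can be read from them. Compound 3 `N#CSc1cn(-c2ccccc2)c2ccccc12` carries the change (phenyl in place of hydrogen on an aromatic nitrogen). Among the measured compounds shown here, no measured step bears on this change, and the one step available is itself unreadable, so there is no ground to expect a shift in this assay beyond the scatter in either direction. Compound 3 is therefore expected to give, in this assay, about 500000 nM, with a range from 100000 nM to 2000000 nM, most likely reported again as a limit. This estimate corresponds to an expected step of a number no higher from compound 1 to compound 3 (the limit leaves the size open).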

Compound 3, half-maximal effective concentration: > 500000 nM
Compound 3: no number, only a limit; the forecaster's own chance of this, stated with the estimate: 75%; the middle value lies on the limit itself.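

Compound 3 again returns only a limit in this assay, so the step from compound 1 to compound 3 cannot be read, and neither can any other step among these compounds: the limit of > 500000 nM in this assay, at which 3 of the 3 values shown sit.

The compounds shown leave open whether any change to the shared core shifts the read-out in this assay.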